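Swapping the amide heteroaryl: an oxadiazole gives way to pyrimidine

A few compounds are considered here, and "the series" means these few. Any claim that something is new, unique, unknown or untested is made for them only; others in the source may bear on it.

Of the compounds shown here, three sharing one core have been measured in a functional assay on isolated protein for inhibition of Glucose-dependent insulinotropic receptor (Rattus norvegicus), read by HTRF and cAMP accumulation; a higher number here means that more compound is needed for the effect, a lower number that less compound is needed. Compound 1 `Cc1nc(S(C)(=O)=O)ccc1Oc1ncnc(OC2CCN(C(=O)C3CCCC3)CC2)c1F` gives 407 nM; compound 2 `Cc1nc(S(C)(=O)=O)ccc1Oc1ncnc(OC2CCN(C(=O)c3noc(C(C)C)n3)CC2)c1F` gives 176 nM; compound 3 `Cc1nc(S(C)(=O)=O)ccc1Oc1ncnc(OC2CCN(C(=O)c3noc(C(C)(C)F)n3)CC2)c1F` gives 103 nM. Compound 3 stands at the lowest number of the three: against compound 2 the gap is within the scatter, against compound 1 it lies beyond it.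

Compound 4 `CCc1cnc(C(=O)N2CCC(Oc3ncnc(Oc4ccc(S(C)(=O)=O)nc4C)c3F)CC2)nc1` differs from compound 3 in one place: a group of 8 heavy atoms (6 carbon, 2 nitrogen; one six-membered aromatic ring with 2 hetero atoms) in place of a group of 9 heavy atoms (5 carbon, 2 nitrogen, 1 oxygen, 1 fluorine; one five-membered aromatic ring with 3 hetero atoms), on a carbonyl carbon. For the measured compounds named here, two measured steps bear on this position. There was a 2.3-fold lower number from compound 1 to compound 2 (0.36 log units; beyond the scatter) and a 4.0-fold lower number from compound 1 to compound 3 (0.60 log units; beyond the scatter), both showing that an aromatic ring on the carbonyl carbon gave a lower number than cyclopentyl. There was also a 1.7-fold lower number from compound 2 to compound 3 (0.23 log units; within the scatter). Going by the values given here, no measured step shows a six-membered ring at this place, so how 5-ethylpyrimidin-2-yl compares with the oxadiazoles is unknown.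

Given that both aromatic amides gave lower numbers than compound 1 in this assay, compound 4 is expected to stay near compound 3, with at most a small rise: the expected step is a 1.7-fold higher number from compound 3 to compound 4 (0.24 log units; within the scatter). The estimate for compound 4 in this assay is 180 nM, within a range of 60 nM to 540 nM.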

Compound 4, half-maximal effective concentration: 40.8 nM
Compound 4: middle estimate off by 4.4-fold (0.64 log units), on the high side; measured number below the stated range.
By their numbers in this assay, from the lowest: compound 4; then compounds 3 and 2 (each within the scatter of the next); then compound 1.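

In this assay, a six-membered aromatic ring on the carbonyl carbon gives the lowest number of the four compounds, and 5-ethylpyrimidin-2-yl goes lower than both oxadiazoles, with a 2.5-fold lower number from compound 3 to compound 4 (0.40 log units; beyond the scatter) and a 4.3-fold lower number from compound 2 to compound 4 (0.63 log units; beyond the scatter) in this series. Against the cyclopentyl amide, the same replacement gives a 10-fold lower number from compound 1 to compound 4 (1.00 log units; beyond the scatter), the widest step among these compounds and the first to show that this position can move the number this far. Nothing available here explains why the pyrimidine gives the lower number.

The compounds shown leave open how much of this step belongs to the ring and how much to its ethyl group. A pyrimidine carrying methyl or a longer chain in place of ethyl would address that, and a phenyl or pyridine ring on the same carbonyl carbon would show whether the ring nitrogens matter.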